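Removing One Chloro From a Shared Core

The source may hold more compounds than are shown below. What is called first, only, known or untested is meant among the compounds shown, and "the series" means these compounds.

Compound 1 `ClCc1ccc(Cn2cnc3nc(Cl)nc(Cl)c32)cc1` and compound 2 `ClCc1cccc(Cn2cnc3c(Cl)nc(Cl)nc32)c1` share a core that carries two chloro groups. In a functional assay on M14 cells (Homo sapiens) for cytotoxicity, read by sulforhodamine B assay, with a stated time of 48 h (on this read-out higher numbers stand for lower toxicity in this test and lower numbers for higher toxicity in this test), compound 1 gives 6910 nM, and compound 2 gives 6450 nM; these two numbers lie within the usual scatter of each other, so neither stands apart. Compound 3 `ClCc1ccc(Cn2cnc3ncnc(Cl)c32)cc1` has not yet been tested. It differs from compound 1 by hydrogen in place of chloro on an aromatic carbon, a hydrogen in place of chloro on an aromatic carbon. Within the data shown here, with no measured step of this kind to lean on, only a modest shift toward a higher number is expected, a 1.4-fold higher number from compound 1 to compound 3 (0.16 log units; within the scatter). Compound 3 is therefore estimated at 10000 nM, with a range from 4000 nM to 30000 nM.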

Compound 3, concentration lethal to 50% of the cells: 37200 nM
Estimate against measurement, compound 3: 3.7-fold (0.57 log units) below, and the stated range ends below it.
By their numbers in this assay, from the lowest: compounds 2 and 1 (each within the scatter of the next); then compound 3.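

Replacing the chloro group between two ring nitrogen atoms with hydrogen gives a 5.4-fold higher number from compound 1 to compound 3 (0.73 log units; beyond the scatter) in this assay. This shows that this single chloro group counts: without it, the number rises beyond the scatter, which here means lower toxicity in this test, even though compound 3 keeps its other chloro group. Nothing measured here explains the size of this change. As far as these compounds go, what an amine or a methoxy group would do at this position remains open. So does the effect of removing the remaining chloro group.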